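The compounds below may be only part of what the source reports. "The series", "measured", "known", "first", "only" and "open" are said of these compounds alone.

Compound 1 `Cn1ncc([N+](=O)[O-])c1C(=O)Nc1ccc2nc(NC(=O)C3CCCCC3)sc2c1` carries a 1-methyl-4-nitro-1H-pyrazol-5-yl group on its carbonyl carbon, and in a functional assay on WI-38 VA13 cells (Homo sapiens) for cytotoxicity (on this read-out lower numbers stand for an effect already at smaller amounts and higher numbers for an effect only at larger amounts of compound), compound 1 gives 0.026 ug/mL, the lowest of the two numbers recorded here. Compound 3 `CCC(C)(C)C(=O)Nc1ccc2nc(NC(=O)C3CCCCC3)sc2c1` gives 1 ug/mL, and the step between them is a 38-fold higher number from compound 1 to compound 3 (1.59 log units; beyond the scatter). Compound 2 `O=C(Nc1ccc2nc(NC(=O)C3CCCCC3)sc2c1)c1ccc(Cl)cc1Cl` reaches only > 4 ug/mL, which is a limit of the assay rather than a number (the limit of > 4 ug/mL in this assay, at which 1 of the 3 values shown sits). The corresponding steps are an at least 150-fold higher number from compound 1 to compound 2 (2.18 log units; beyond the scatter) and an at least 4.0-fold lower number from compound 2 to compound 3 (0.60 log units; beyond the scatter). Compound 4 `O=C(Nc1ccc2nc(NC(=O)C3CCCCC3)sc2c1)c1cccnc1Cl` differs from compound 1 by 2-chloropyridin-3-yl in place of 1-methyl-4-nitro-1H-pyrazol-5-yl on a carbonyl carbon. Both measured departures from the pyrazolyl group, whether to an aromatic ring or to an alkyl branch, were large moves toward higher numbers, so a large step in the same direction is expected for compound 4 in this assay. The step of an at least 150-fold higher number from compound 1 to compound 2 (2.18 log units; beyond the scatter), in which a six-membered aromatic ring likewise entered, is taken as the closer guide. The expected step for compound 4 is a 58-fold higher number from compound 1 to compound 4 (1.76 log units; beyond the scatter). Compound 4 is therefore estimated at 1.5 ug/mL, with a range from 0.4 ug/mL to 4 ug/mL.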

Compound 4, half-maximal effective concentration: 0.075 ug/mL
For compound 4 the middle estimate is 20-fold (1.30 log units) above the measured one; measured number outside the range, below it.
By their numbers in this assay, from the lowest: compound 1; then compound 4; then compound 3. At a limit, above all of these: compound 2.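

With a 2.9-fold higher number from compound 1 to compound 4 (0.46 log units; beyond the scatter) against a 13-fold lower number from compound 3 to compound 4 (1.12 log units; beyond the scatter), the 2-chloropyridin-3-yl group shows that a low number in this assay on this carbonyl carbon does not require the 1-methyl-4-nitro-1H-pyrazol-5-yl group. A six-membered aromatic ring alone does not set the outcome either, as two such rings on this carbon are separated by an at least 53-fold lower number from compound 2 to compound 4 (1.72 log units; beyond the scatter). Compound 2 stands at a limit of the assay, not at a number: the limit of > 4 ug/mL in this assay, at which 1 of the 4 values shown sits.

The compounds shown do not separate the ring nitrogen of the 2-chloropyridin-3-yl group from its chlorine, as the two differ together from the 2,4-dichlorophenyl group. As far as these compounds go, how an unsubstituted pyridin-3-yl group or a 2-methoxypyridin-3-yl group on the same carbonyl carbon would read remains open.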